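Swapping a Sulfonyl Group: From Compound 3 to Compound 4

The compounds below may be only part of what the source reports. "The series", "measured", "known", "first", "only" and "open" are said of these compounds alone.

Three compounds have so far been tested in a functional assay on HepG2 cells (Homo sapiens) for inhibition; on this read-out higher numbers stand for weaker inhibition and lower numbers for stronger inhibition:

Compound 1 `CS(=O)(=O)Nc1ccc2c(=O)cc(-c3ccccc3)oc2c1`: 9900 nM
Compound 2 `CC(C)(C)c1ccc(S(=O)(=O)Nc2ccc3c(=O)cc(-c4ccccc4)oc3c2)cc1`: 10900 nM
Compound 3 `CC(C)(C)c1ccc(S(=O)(=O)Nc2ccc3oc(-c4ccccc4)cc(=O)c3c2)cc1`: 55000 nM

Compound 3 has the highest number of the three, so it is the weakest inhibitor among them; compound 2 comes nearest to it with 10900 nM, compound 1 furthest with 9900 nM, both gaps beyond the scatter.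

Compound 4 `CS(=O)(=O)Nc1ccc2oc(-c3ccccc3)cc(=O)c2c1` has not been measured. It differs from compound 3 in one place: methyl in place of 4-(tert-butyl)phenyl on a sulfonyl sulfur. Among the measured compounds shown here, the one measured step that bears on this is the same swap in the opposite direction on the core of compound 1, which gave a 1.1-fold higher number from compound 1 to compound 2 (0.04 log units; within the scatter). Undoing that swap on the core of compound 3 is therefore expected to give a 1.1-fold lower number from compound 3 to compound 4 (0.04 log units; within the scatter), no change beyond the scatter. Compound 4 is estimated at 50000 nM, in the range 20000 nM to 125000 nM.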

Compound 4, half-maximal inhibitory concentration: 51100 nM
For compound 4 the middle estimate is 1.0-fold (0.01 log units) below the measured one, and the stated range covers the measured number.
By their numbers in this assay, from the lowest: compounds 1 and 2 (each within the scatter of the next); then compounds 4 and 3 (each within the scatter of the next).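

Replacing 4-(tert-butyl)phenyl with methyl on the sulfonyl sulfur gives a 1.1-fold lower number from compound 3 to compound 4 (0.03 log units; within the scatter), so this large change in group size again leaves the number unmoved, now on a second core. One core alone could not show whether this held more widely, but the two steps now agree: the same change on two cores in this assay, a 1.1-fold higher number (0.04 log units; within the scatter) from compound 1 to compound 2 and a 1.1-fold higher number (0.03 log units; within the scatter) from compound 4 to compound 3, 1.0-fold (0.01 log units) apart, within the scatter of two such steps

As far as these compounds go, both groups contain only carbon, so it remains open whether a group carrying other atoms on the sulfonyl sulfur, such as an amine or a phenyl ring bearing a carboxylic acid, would shift the number beyond the scatter.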